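The source may report more compounds than this note shows. Statements on the series, on what has been measured and on what is new or still open speak of the compounds shown alone.

Compound 1, `Cc1ccc(C#Cc2cn(C/C=C\CN3C(=O)c4ccccc4C3=O)c(=O)[nH]c2=O)cc1`, in a functional assay on L1210 cells (Mus musculus) for antiproliferative activity, read by MTT assay, with a stated time of 2 days (a higher number here means a weaker inhibitor, a lower number a stronger inhibitor), gives 245000 nM.
Compound 2, `O=C1c2ccccc2C(=O)N1C/C=C\Cn1cc(C#Cc2ccc(Br)cc2)c(=O)[nH]c1=O`, in this assay gives 448000 nM.

Within the data shown here, only two compounds have been measured, and they share one core. The single measured step, a 1.8-fold higher number from compound 1 to compound 2 (0.26 log units; within the scatter), lies within the usual scatter, so compound 2 and compound 1 stand together rather than apart on the numbers shown. The unmeasured compound 3, `CCCCCc1ccc(C#Cc2cn(C/C=C\CN3C(=O)c4ccccc4C3=O)c(=O)[nH]c2=O)cc1`, differs from compound 2 by pentyl in place of bromo on an aromatic carbon. Among the measured compounds shown here, the one step that bears on this place, a 1.8-fold higher number from compound 1 to compound 2 (0.26 log units; within the scatter), exchanged two small groups there without moving the number beyond the scatter; no step with a pentyl chain, or with any longer chain, is available at all. On that thin basis the step from compound 2 to compound 3 in this assay is expected to be small, a 1.3-fold lower number from compound 2 to compound 3 (0.11 log units; within the scatter), with no direction that can be trusted. Compound 3 is therefore estimated at 350000 nM, within a range from 120000 nM to 1000000 nM.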

Compound 3, half-maximal inhibitory concentration: 28000 nM
Compound 3: middle estimate off by 13-fold (1.10 log units), on the high side, outside the stated range (below it).
By their numbers in this assay, from the lowest: compound 3; then compounds 1 and 2 (each within the scatter of the next).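

Methyl and bromo on this aromatic carbon gave numbers within the scatter of each other, so the position looked indifferent to what sits there, but the pentyl chain changes that picture: in this assay there is a 16-fold lower number from compound 2 to compound 3 (1.20 log units; beyond the scatter). Extending the methyl of compound 1 into the same chain gives a similar picture, with an 8.8-fold lower number from compound 1 to compound 3 (0.94 log units; beyond the scatter), so compound 3 is the strongest inhibitor of the three whichever group it is compared with. No measurement shown explains why the pentyl chain has this effect.

From the compounds shown here alone, with only one chain in the set, it remains open whether shorter chains such as ethyl or propyl would already lower the number. A longer chain such as octyl, or a chain ending in an amine or a carboxylic acid, could lower it further or reverse the change.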